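The source may report more compounds than this note shows. Statements on the series, on what has been measured and on what is new or still open speak of the compounds shown alone.

Compound 1 `S=C(Nc1ccccc1)Nc1ccc2[nH]ccc2c1` carries a thiourea linking a plain phenyl group to the shared core. In an ADME assay on cells for inhibition of Amine oxidase [flavin-containing] A (Homo sapiens), read by spectrophotometry (a higher number here means a weaker inhibitor, a lower number a stronger inhibitor), compound 1 gives > 30000 nM, which is a limit of the assay and not a number. Compound 2 `Oc1ccccc1NC(=S)Nc1ccc2[nH]ccc2c1` gives 39000 nM in this assay, and compound 3 `Oc1cccc(NC(=S)Nc2ccc3[nH]ccc3c2)c1` is recorded in this assay as "not active" (no number reported), with no number reported. Among the compounds with values here, the one measured step that touches compound 1, a step that the limit leaves unreadable from compound 1 to compound 2, cannot be read in size because of the limit of > 30000 nM in this assay, at which 1 of the 3 values shown sits, so the three compounds together say only that none of them reaches a number well inside the measurable range.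

Compound 4 `Oc1ccc(NC(=S)Nc2ccc3[nH]ccc3c2)cc1` differs from compound 1 in one place: hydroxy in place of hydrogen on an aromatic carbon. The measured step from compound 1 to compound 2 introduces the same group on another carbon of the same ring and leaves the value where compound 1 sits or beyond it, and compound 3 shows no activity at all. On that evidence no movement beyond the scatter is expected, and the step is estimated as a step that the limit leaves unreadable from compound 1 to compound 4. Compound 4 is therefore expected to give about 40000 nM in this assay, somewhere between 15000 nM and 120000 nM, with a real chance that only a limit is reported.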

Compound 4, half-maximal inhibitory concentration: "not active" (no number reported)
The entry for compound 4 holds no number, and the estimate cannot be compared.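

Compound 4 carries no number in this assay and compound 1 stands only at a limit, so no step between compound 1 and compound 4 can be read: the limit of > 30000 nM in this assay, at which 1 of the 4 values shown sits.

The compounds shown leave open whether any change to the plain phenyl group of compound 1 can bring a value well inside the measurable range.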